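From a Dimethylmorpholine to a Bicyclic Amine

The source may hold more compounds than are shown below. What is called first, only, known or untested is meant among the compounds shown, and "the series" means these compounds.

Compound 3, `COc1ccc2[nH]c(C(=O)N3CC(=O)N(Cc4ccccc4)[C@@H](CN4[C@H](C)COC[C@@H]4C)C3)cc2c1`, carries a 3,5-dimethylmorpholin-4-yl group on a saturated chain carbon bound to a saturated ring carbon. In a physicochemical assay for solubility, read by spectrophotometry, in phosphate buffer, with a stated time of 2 h, at pH 7.4 (on this read-out lower numbers stand for lower solubility and higher numbers for higher solubility), compound 3 reaches only a limit, > 100000 nM. Compound 2, `COc1ccc2[nH]c(C(=O)N3CC(=O)N(Cc4ccccc4)[C@@H](Cc4ccccn4)C3)cc2c1`, likewise stops at a limit in this assay, > 100000 nM. Compound 1, `COc1ccc2[nH]c(C(=O)N3CC(=O)N(Cc4ccccc4)[C@@H](CN4CCCCC4)C3)cc2c1`, stops at another limit in this assay, > 25000 nM. Because of the limit of > 100000 nM in this assay, at which 2 of the 3 values shown sit, and the limit of > 25000 nM in this assay, at which 1 of the 3 values shown sits, none of the three steps can be sized: a step that the two limits leave unreadable from compound 1 to compound 2, a step that the two limits leave unreadable from compound 1 to compound 3 and a step that the two limits leave unreadable from compound 2 to compound 3 all remain unreadable. Compound 4, `COc1ccc2[nH]c(C(=O)N3CC(=O)N(Cc4ccccc4)[C@@H](CN4CC5CCCCC5C4)C3)cc2c1`, differs from compound 3 by a group of 9 heavy atoms (8 carbon, 1 nitrogen; one five-membered non-aromatic ring with 1 hetero atom, one six-membered non-aromatic ring of carbon only) in place of a group of 8 heavy atoms (6 carbon, 1 nitrogen, 1 oxygen; one six-membered non-aromatic ring with 2 hetero atoms), on a saturated chain carbon bound to a saturated ring carbon. Within the data shown here, no measured step therefore bears readably on this change, and the numbers give neither a size nor a direction to carry forward. The step that the estimate implies, an at least 2.5-fold lower number from compound 3 to compound 4 (0.39 log units; beyond the scatter), is accordingly expected to be modest and uncertain in sign. Compound 4 is expected to give 40000 nM in this assay, within a range from 8000 nM to 150000 nM.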

Compound 4, solubility: 23800 nM
The estimate for compound 4 lay 1.7-fold (0.23 log units) above the measured number; measured number inside the range.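

Compound 4 gives the only read number shown in this assay, and changes on a saturated chain carbon bound to a saturated ring carbon now show a direction. Its group in place of 3,5-dimethylmorpholin-4-yl gives an at least 4.2-fold lower number from compound 3 to compound 4 (0.62 log units; beyond the scatter), and in place of pyridin-2-yl it gives an at least 4.2-fold lower number from compound 2 to compound 4 (0.62 log units; beyond the scatter), so the group at this place does matter to the read-out. In place of piperidin-1-yl it gives only an at least 1.0-fold lower number from compound 1 to compound 4 (0.02 log units; that floor lies within the scatter), which settles no order, and the steps among compound 1, compound 2 and compound 3 remain unreadable.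

In compound 3 and compound 4 the ring and the ring oxygen change together, and the compounds shown do not separate the two. Also open, as far as these compounds go, is what morpholin-4-yl without its two methyl groups, or a carboxylic acid on the same chain carbon, would give.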